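The compounds below may be only part of what the source reports. "The series", "measured", "known", "first", "only" and "open" are said of these compounds alone.

Three compounds share one core. Compound 1 `CCONC(=N)c1ccc2[nH]c(-c3cccc(-c4ccccc4O)c3O)cc2c1` carries ethoxy on an amine nitrogen, and in a physicochemical assay for solubility, in phosphate buffer, at pH 7.4 (on this read-out higher numbers stand for higher solubility and lower numbers for lower solubility), compound 1 gives 43000 nM. Compound 2 `CCOC(=O)NC(=N)c1ccc2[nH]c(-c3cccc(-c4ccccc4O)c3O)cc2c1` carries ethoxycarbonyl in that place instead. In this assay compound 2 reaches only a limit of the measurement, < 10000 nM. Compound 3 `CC(C)OC(=O)NC(=N)c1ccc2[nH]c(-c3cccc(-c4ccccc4O)c3O)cc2c1` carries isopropoxycarbonyl there. In this assay compound 3 likewise sits at a limit, < 10000 nM. The two steps read an at least 4.3-fold lower number from compound 1 to compound 2 (0.63 log units; beyond the scatter) and an at least 4.3-fold lower number from compound 1 to compound 3 (0.63 log units; beyond the scatter); both rest on (the limit of < 10000 nM in this assay, at which 2 of the 3 values shown sit). The step between the two carbamates is a step that the two limits leave unreadable from compound 2 to compound 3, so it cannot be read. Compound 3 therefore stands at a limit, with one of the other two values at that same limit.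

Compound 4 `CC(=O)OC(C)OC(=O)NC(=N)c1ccc2[nH]c(-c3cccc(-c4ccccc4O)c3O)cc2c1` differs from compound 3 by acetoxy in place of methyl on a saturated chain carbon bound to an oxygen next to a carbonyl group and a saturated chain carbon, which in full reads isopropoxycarbonyl to (1-acetoxyethoxy)carbonyl. Within the data shown here, no measured step covers a change of this kind, and the starting value is itself a limit, so little can be read forward. The step expected in this assay is a step that the limit leaves unreadable from compound 3 to compound 4, and the result may well again be only a limit. The expected value for compound 4 is 8000 nM, between 2000 nM and 30000 nM.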

Compound 4, solubility: < 10000 nM
Compound 4 was reported as a limit; the forecaster's own chance of this, stated with the estimate: 50%; the middle value lies beyond the limit too.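

In this assay, among these compounds, compound 4 is reported only as a limit, so swapping methyl for acetoxy gives no size that can be set against the earlier compounds. Among the compounds shown here, the steps among compound 2, compound 3 and compound 4 cannot be read, and the one step that can be read is an at least 4.3-fold lower number from compound 1 to compound 4 (0.63 log units; beyond the scatter). The result adds (1-acetoxyethoxy)carbonyl to ethoxycarbonyl and isopropoxycarbonyl as a third group on the amine nitrogen that reads lower than ethoxy, and all comparison among the three stops at one shared limit: the limit of < 10000 nM in this assay, at which 3 of the 4 values shown sit.

Going by these compounds, how compound 2, compound 3 and compound 4 rank against each other stays open. So does whether an amine or a carboxylic acid in the place of acetoxy would give a value above that limit.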